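The compounds below may be only part of what the source reports. "The series", "measured", "known", "first", "only" and "open" are said of these compounds alone.

Of the compounds shown here, two have so far been measured in an assay on isolated protein for binding affinity to leukotriene B4 receptor 1 (Homo sapiens), tested at 1 uM; a higher number here means more inhibition at the concentration tested (going by the name of the read-out), a lower number less inhibition. Compound 1 `CCc1cc(C(C)=O)c(O)cc1OCCCC(C)(C)c1nnn[nH]1` gives 76% in this assay, while compound 2 `CCc1cc(C(C)=O)c(O)cc1OCCCCCC(C)(C)c1nnnn1C` gives 59%, the lower of the two numbers, sitting below compound 1 by a gap beyond the usual scatter. Compound 3 `CCc1cc(C(C)=O)c(O)cc1OCCCCCCSC` has not yet been measured; it differs from compound 2 by (methylsulfanyl)methyl in place of 1-methyl-1-(1-methyl-1H-tetrazol-5-yl)ethyl on a saturated chain carbon, five bonds along the chain from an oxygen on an aromatic ring. Among the measured compounds shown here, no measured pair covers this change, so any expectation rests on compound 2 alone. Compound 3 is expected to show a downward step of a number 29 percentage points lower from compound 2 to compound 3 (beyond the scatter) in this assay. The estimated inhibition of compound 3 is 30%, between 5% and 60%.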

Compound 3, a percentage reported as inhibition, at one concentration (the size of the read-out at that concentration, not a potency): 14%
The estimate for compound 3 lay 16 percentage points above the measured number; the measured number falls inside the stated range.
By their numbers in this assay, from the lowest: compound 3; then compound 2; then compound 1.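

In this assay, (methylsulfanyl)methyl in place of 1-methyl-1-(1-methyl-1H-tetrazol-5-yl)ethyl gives a number 45 percentage points lower from compound 2 to compound 3 (beyond the scatter), and 3-(methylsulfanyl)propyl in place of 1-(1H-tetrazol-5-yl)-1-methylethyl gives a number 62 percentage points lower from compound 1 to compound 3 (beyond the scatter). Among these three compounds, then, the group at the end of the chain matters greatly, and both tetrazole-bearing groups retain far more inhibition than the sulfur-ending chain. Nothing available explains this loss.

From the compounds shown here alone, it remains open whether the tetrazole ring itself or the rest of the departing group accounts for the difference. A carboxylic acid at the chain end would help to test whether another group can replace the tetrazole.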